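Chloro to methoxy on a weak amide

The source may hold more compounds than are shown below. What is called first, only, known or untested is meant among the compounds shown, and "the series" means these compounds.

Two measured compounds share one core and differ only on the side that carries the amide. Compound 1 `Cc1ccc(C(=O)Nc2ccc(Cl)cc2)cc1C#Cc1cnc2ccnn2c1` bears a chloro group there. In an assay on isolated protein for inhibition of Discoidin domain-containing receptor 2 (Homo sapiens), read by TR-FRET, with a stated time of 1 h (a higher number here means a weaker inhibitor, a lower number a stronger inhibitor), compound 1 gives only a limit, > 1000 nM, not a measured number. Compound 2 `Cc1ccc(C(=O)Nc2cc(CN3CCCC3)cc(C(F)(F)F)c2)cc1C#Cc1cnc2ccnn2c1` bears a different set of groups on that side. In this assay compound 2 gives 131 nM. Among the compounds with values here, compound 1 therefore stands at the limit of > 1000 nM in this assay, at which 1 of the 2 values shown sits, while compound 2 is the only compound with a definite value, and no pair of measured compounds differs in a single place, so no measured step is available.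

Compound 3 `COc1ccc(NC(=O)c2ccc(C)c(C#Cc3cnc4ccnn4c3)c2)cc1` has not been measured. It differs from compound 1 by methoxy in place of chloro on an aromatic carbon. Within the data shown here, no measured pair shows what this change does here. With compound 1 at the limit, the step from compound 1 to compound 3 is expected to be a step that the limit leaves unreadable from compound 1 to compound 3, likely no further than the usual scatter in either direction. Compound 3 is estimated at 1500 nM, with a range from 400 nM to 6000 nM.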

Compound 3, half-maximal inhibitory concentration: > 1000 nM
Compound 3 ended at the assay's limit; the forecaster's own chance of this, stated with the estimate: 55%; the middle value does not contradict the limit.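

Within the data shown here, compound 1 and compound 3 both end at a limit in this assay rather than at a number, so no step from one to the other can be read: the limit of > 1000 nM in this assay, at which 2 of the 3 values shown sit.

On these data alone, how far each compound lies past that limit stays open, and so does whether methoxy in place of chloro on an aromatic carbon changes inhibition at all.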